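Quinazoline series: swapping the piperazine aryl cap

This account rests on a few compounds, and the source may have more. Where it says the series, first, only, none or still open, it means among the compounds named here.

Measured compounds: compound 1 `COc1ccnc(N2CCN(c3nc(N)c4cc(OC)c(OC)cc4n3)CC2)n1` with 0.19 nM in an assay on brain for binding affinity to Adrenergic receptor alpha-1 (Rattus norvegicus); on this read-out higher numbers stand for weaker inhibition and lower numbers for stronger inhibition; compound 2 `COc1cc2nc(N3CCN(c4nccc(N(C)C)n4)CC3)nc(N)c2cc1OC` with 0.27 nM in this assay.

Among the measured compounds shown here, compound 2 carries the higher of the two numbers, but the one step recorded so far, a 1.4-fold higher number from compound 1 to compound 2 (0.15 log units; within the scatter), lies within the scatter, so compounds 1 and 2 are indistinguishable on these data.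

Compound 3 `COc1cc2nc(N3CCN(c4ccc(OC(C)C)nn4)CC3)nc(N)c2cc1OC` is not yet measured. The change from compound 2 is 6-isopropoxypyridazin-3-yl in place of 4-(dimethylamino)pyrimidin-2-yl on an amine nitrogen in a ring: the whole aromatic cap on the piperazine nitrogen is exchanged, not a single substituent as in the step from compound 1 to compound 2. For the measured compounds named here, no measured pair bears directly on this exchange; the only step available shows that varying the group on that cap left the number within the scatter. Compound 3 is therefore expected to stay in the same sub-nanomolar region, with a step of a 1.5-fold higher number from compound 2 to compound 3 (0.17 log units; within the scatter) that need not exceed the scatter, though the wider range reflects the larger change. The estimate for compound 3 in this assay is 0.4 nM, between 0.1 nM and 1.6 nM.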

Compound 3, inhibition constant: 0.29 nM
Compound 3: the middle estimate sits 1.4-fold (0.14 log units) above what was measured; measured number inside the range.
By their numbers in this assay, from the lowest: compounds 1, 2 and 3 (each within the scatter of the next).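

In this assay, replacing the whole aromatic cap on an amine nitrogen in a ring gives a 1.1-fold higher number from compound 2 to compound 3 (0.03 log units; within the scatter), and the comparison with the methoxy-bearing cap gives a 1.5-fold higher number from compound 1 to compound 3 (0.18 log units; within the scatter). Both steps lie within the scatter, so the tolerance seen earlier for a change of one substituent on the cap now also covers an exchange of the cap itself, with 6-isopropoxypyridazin-3-yl indistinguishable from 4-(dimethylamino)pyrimidin-2-yl and 4-methoxypyrimidin-2-yl at this position. No supporting data are available to explain this flat result.

Still open, on these data alone, is whether the numbers stay this close with a plain phenyl or a saturated cyclohexyl cap on that nitrogen. Equally open, as far as these compounds go, is the outcome for a cap carrying a carboxylic acid or a longer alkoxy chain.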